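The source may hold more compounds than are shown below. What is called first, only, known or untested is meant among the compounds shown, and "the series" means these compounds.

Working notes on the series in a toxicity assay on THP-1 cells (Homo sapiens) for inhibition (on this read-out lower numbers stand for higher toxicity in this test and higher numbers for lower toxicity in this test), follow. Compound 1 (`COc1ccc(-c2cnc(NC(=O)c3ccc(F)cc3)n2Cc2ccccc2)cc1`) reads > 100000 nM as a limit of the assay. Compound 2 (`COc1ccc(-c2cnc(NC(=O)c3ccccc3O)n2C)cc1`) reads > 100000 nM as a limit too, so it has no number of its own and stands only on the limit of > 100000 nM in this assay, at which 2 of the 3 values shown sit, as its position. Compound 3 (`Cn1c(-c2ccccc2Cl)cnc1NC(=O)c1ncc[nH]1`) reads > 50000 nM as a limit as well.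

Next comes compound 4 (`COc1ccc(-c2cnc(NC(=O)CCc3ccccc3)n2C)cc1`), with phenethyl in place of 2-hydroxyphenyl on a carbonyl carbon. Going by the values given here, no two measured compounds differ in one place, so the series offers no measured size for such a change. The expected a number no higher from compound 2 to compound 4 (the limit leaves the size open) in this assay stays within the scatter, with no direction favoured. That expectation starts from compound 2, whose limit of > 100000 nM is the only reference point. A report of a limit alone is also expected to be likely for compound 4. For compound 4 the estimated value is 100000 nM, with an expected range from 40000 nM to 150000 nM in this series.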

Compound 4, half-maximal cytotoxic concentration: > 100000 nM
Compound 4: a limit, no number (the forecaster's own chance of this, stated with the estimate: 80%); the middle value lies on the limit itself.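

Compound 2 and compound 4 are both reported only as limits in this assay, so no step can be read between them. The compounds shown leave open whether phenethyl in place of 2-hydroxyphenyl on a carbonyl carbon changes the read-out at all, and by how much.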